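The compounds below may be only part of what the source reports. "The series", "measured", "known", "first", "only" and "open" are said of these compounds alone.

Measured in a functional assay on PC-3 cells (Homo sapiens) for inhibition, read by MTT assay, with a stated time of 24 h; a lower number here means a stronger inhibitor, a higher number a weaker inhibitor:

- compound 1 `CCOC1c2cc(OCc3cc(C)cc(C)c3)c(OCc3cc(C)cc(C)c3)cc2CCN1C(=O)OC(C)(C)C`: > 20000 nM
- compound 2 `CC[C@@H]1C[C@H](O)C/C=C(/C)[C@H]2c3cc(OCc4ccccc4)c(OCc4ccccc4)cc3CCN12`: > 20000 nM
- compound 3 `CCC[C@@H]1C[C@H](O)C/C=C(/CC)[C@H]2c3cc(OCc4ccccc4)c(OCc4ccccc4)cc3CCN12`: > 20000 nM

Each of these entries is a limit of the assay and not a number. Compound 1 therefore has no measured strength to rank, and its place is simply this: the limit of > 20000 nM in this assay, at which 3 of the 3 values shown sit.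

Compound 4 `Cc1cc(C)cc(COc2cc3c(cc2OCc2cc(C)cc(C)c2)CN(C(=O)OC(C)(C)C)CC3)c1` is compound 1 with a single change: hydrogen in place of ethoxy on a saturated ring carbon. In words, hydrogen stands in place of ethoxy on a saturated ring carbon, next to the ring nitrogen.

Within the data shown here, no pair of measured compounds differing in one place exists in this assay, so no measured step can guide this change. Among the measured compounds shown here, the only anchor is compound 1, with its limit of > 20000 nM. A step beyond the usual scatter is therefore not expected, in either direction, and compound 4 will most likely also be reported only as a limit. The expected change is a step that the limit leaves unreadable from compound 1 to compound 4. For compound 4 the estimated value is 25000 nM, with an expected range of 10000 nM to 60000 nM.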

Compound 4, half-maximal inhibitory concentration: > 20000 nM
Compound 4 ended at the assay's limit; the forecaster's own chance of this, stated with the estimate: 80%; the middle value is on the limit's open side.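

Compound 1 and compound 4 each give only a limit and not a number, so the step between them cannot be read: the limit of > 20000 nM in this assay, at which 4 of the 4 values shown sit.

The compounds shown leave open whether hydrogen in place of ethoxy changes strength at all, and which structure would give a measurable value in this assay at all.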